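Methoxy to hydroxy on the aryl group of compound 2

A few compounds are considered here, and "the series" means these few. Any claim that something is new, unique, unknown or untested is made for them only; others in the source may bear on it.

Working notes on a small series read in a functional assay on UACC-62 cells (Homo sapiens) for cytotoxicity, read by sulforhodamine B assay, with a stated time of 48 h, tested at 0.01 uM; a lower number here means a stronger effect, a higher number a weaker effect of the compound at the concentration tested. Of the compounds shown here, three carry numbers so far. Compound 1 `COc1cc(C)cc(-c2c(-c3ccnc(-c4ccc(N(C)C)cc4)c3)cnn2CC#N)c1` gives 38% in this assay. Compound 2 `COc1cc(C)cc(-c2nn(CC#N)cc2-c2ccnc(-c3ccc(N(C)C)cc3)c2)c1` gives 86% in this assay. Compound 3 `COc1cc(C)cc(-c2nn(CC#N)cc2-c2ccc(-c3cccc(C(C)=O)c3)nc2)c1` gives 90% in this assay.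

Compound 2 stands second highest of the three numbers. Its nearest neighbour is compound 3, whose number sits a few points higher, within the usual scatter, so no order between compound 2 and compound 3 can be read from these two values. Its furthest neighbour is compound 1, whose number lies well below that of compound 2, beyond the scatter.

The next compound, compound 4 `Cc1cc(O)cc(-c2nn(CC#N)cc2-c2ccnc(-c3ccc(N(C)C)cc3)c2)c1`, differs from compound 2 in one place only: hydrogen in place of methyl on an oxygen on an aromatic ring. Among the compounds with values here, no pair of measured compounds shows this change, so there is no measured step to lean on. The change is small by what is counted, and nothing among the three measured compounds points in either direction.

The expectation for compound 4 is therefore a step of about a number 4 percentage points lower from compound 2 to compound 4 (within the scatter), which is no change beyond the scatter. The estimate for compound 4 in this assay is 82%, with a range from 62% to 96%.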

Compound 4, a percentage reported as activity, at one concentration (the size of the read-out at that concentration, not a potency): 96%
For compound 4 the middle estimate is 14 percentage points below the measured one; the measured number falls inside the stated range.
By their numbers in this assay, from the lowest: compound 1; then compounds 2, 3 and 4 (each within the scatter of the next).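

In this assay, within the data shown here, the exchange of methoxy for hydroxy on the aryl group reads as a number 10 percentage points higher from compound 2 to compound 4 (within the scatter) and is the first measured step at this place. The methyl on this oxygen can give way to hydrogen, turning 3-methoxy-5-methylphenyl into 3-hydroxy-5-methylphenyl, without a shift beyond the scatter, and compound 4 at 96% does not separate from compound 2 in this read-out at a single concentration. Nothing on hand bears on what lies behind this result.

Open, from the compounds shown here alone, is whether a longer chain on this oxygen, or an amine or a carboxylic acid in place of the hydroxy, would read differently in this assay from the two groups seen so far. Among these compounds, also open is whether the same exchange on the core of compound 1, which gives 38% in this read-out, would produce a step of similar size, since the one step in hand comes from the core of compound 2 alone.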